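This account rests on a few compounds, and the source may have more. Where it says the series, first, only, none or still open, it means among the compounds named here.

Measured so far:
compound 1 `CC(=O)N1N=C(c2ccc(OCc3cn(Cc4ccc([N+](=O)[O-])cc4)nn3)cc2)CC1c1ccccc1`: 80%
compound 2 `COc1cc(C2CC(c3ccc([N+](=O)[O-])cc3)=NN2C(C)=O)ccc1OCc1cn(Cc2ccc([N+](=O)[O-])cc2)nn1`: 72%
compound 3 `COc1cc(C2CC(c3cccc4ccccc34)=NN2C(C)=O)ccc1OCc1cn(Cc2ccc([N+](=O)[O-])cc2)nn1`: 95%

In a functional assay on A549 cells (Homo sapiens) for inhibition, read by sulforhodamine B assay, tested at 100 uM (a higher number here means more inhibition of growth at the concentration tested, a lower number less inhibition of growth), compound 1 and compound 2 lie within the usual scatter of each other, while compound 3 stands higher than compound 1 by a margin beyond the scatter. Compound 4 `COc1ccc(C2CC(c3ccc(OCc4cn(Cc5ccc([N+](=O)[O-])cc5)nn4)cc3)=NN2C(C)=O)cc1OC` differs from compound 1 by 3,4-dimethoxyphenyl in place of phenyl on a saturated ring carbon.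

Among the measured compounds shown here, the only single-point step measured, a number 23 percentage points higher from compound 2 to compound 3 (beyond the scatter), concerns the carbon with a double bond to nitrogen, not the saturated ring carbon, and so does not bear on this change. Compounds 1 and 2 differ in more than one place; their values sit within the scatter of each other. On this basis no step beyond the scatter is expected, a number 2 percentage points lower from compound 1 to compound 4 (within the scatter). Compound 4 is estimated at 78%, with a range of 60% to 95%.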

Compound 4, percent growth inhibition at one concentration: 36%
Estimate against measurement, compound 4: 42 percentage points above, and the stated range ends above it.
By their numbers in this assay, from the lowest: compound 4; then compounds 2 and 1 (each within the scatter of the next); then compound 3.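

The saturated ring carbon does not tolerate every aryl group in this assay: 3,4-dimethoxyphenyl in place of phenyl gives a number 44 percentage points lower from compound 1 to compound 4 (beyond the scatter) on the core of compound 1. Among the compounds shown here, the earlier step concerned only the carbon with a double bond to nitrogen, so this is the first evidence that the saturated ring carbon matters. Nothing at hand accounts for this drop.

On these data alone, whether it needs both methoxy groups or only one remains open. As far as these compounds go, the outcome with a hydroxyl group or an amine on that phenyl also remains open.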